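This account rests on a few compounds, and the source may have more. Where it says the series, first, only, none or still open, it means among the compounds named here.

Measured in an ADME assay on MRC5 cells (Homo sapiens) for antiproliferative activity, read by fluorescence and resazurin assay, with a stated time of 68 h; a lower number here means that less compound is needed, a higher number that more compound is needed for the effect:
- compound 1 `Cc1ccc(-c2cc(C(=O)Nc3cccnc3)c3cc(Cl)ccc3n2)cc1`: 21000 nM
- compound 2 `Cc1ccc(-c2cc(C(=O)Nc3cccnc3)c3cc(F)ccc3n2)cc1`: 50000 nM
- compound 3 `Cc1ccc(-c2cc(C(=O)Nc3cccnc3)c3ccccc3n2)cc1`: > 50000 nM (a limit of the assay, not a number)

Of the two compounds with a true number, compound 1 stands lowest at 21000 nM. Compound 2 is its nearest neighbour: a 2.4-fold higher number from compound 1 to compound 2 (0.38 log units; beyond the scatter). Compound 3 gives only a limit, > 50000 nM.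

Compound 4 `Cc1ccc(-c2cc(C(=O)NCCN(C)C)c3cc(Cl)ccc3n2)cc1` keeps the chloro of compound 1 and changes the amide instead: 2-(dimethylamino)ethyl in place of pyridin-3-yl on an amide-type nitrogen. In words, 2-(dimethylamino)ethyl stands in place of pyridin-3-yl on an amide-type nitrogen.

The measured steps offer little guidance on this change. All of them swap the group on an aromatic carbon and leave the amide untouched: a 2.4-fold higher number from compound 1 to compound 2 (0.38 log units; beyond the scatter), an at least 2.3-fold higher number from compound 1 to compound 3 (0.37 log units; beyond the scatter) and a number no lower from compound 2 to compound 3 (the limit leaves the size open). The first two are modest in size, and the limit leaves the size of the third open. None shows what a new amide group does, so the expectation rests on compound 1, which gives 21000 nM. On these data alone, the estimated step is a 1.1-fold lower number from compound 1 to compound 4 (0.02 log units; within the scatter), which means no clear change is expected in this assay, and the direction stays open. For compound 4 the expected value is 20000 nM, within an estimated range of 6000 nM to 50000 nM.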

Compound 4, half-maximal effective concentration: 9000 nM
For compound 4 the middle estimate is 2.2-fold (0.35 log units) above the measured one; measured number inside the range.
By their numbers in this assay, from the lowest: compound 4; then compound 1; then compound 2.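

Compounds 1, 2 and 3 differ only in the group on an aromatic carbon of the shared core, so compound 4 alone shows what a change on the amide-type nitrogen does. In this assay, putting 2-(dimethylamino)ethyl in place of pyridin-3-yl gives a 2.3-fold lower number from compound 1 to compound 4 (0.37 log units; beyond the scatter), a modest step that shows the aromatic ring at this place is not needed for the effect, at least while the chloro stays in place: an open chain with no ring gives the lower number here. No measurement shown here speaks to the cause of this step.

This single chain cannot show whether the length of the chain or its amine end matters, so a shorter or longer chain, a primary amine, or a morpholine ring at the same nitrogen could each move the number either way. On these data alone, it also remains open whether the same exchange would give a similar step with the fluoro of compound 2 or the hydrogen of compound 3 on the aromatic carbon, rather than the chloro of compound 1.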